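The source may report more compounds than this note shows. Statements on the series, on what has been measured and on what is new or still open speak of the compounds shown alone.

Compound 1 `Cc1cn2c(-c3cn[nH]c3)cnc2c(Nc2cc(CN3CCCCC3(C)C)ns2)n1` gives 211 ng.h/mL.
Compound 2 `CCOC(=O)N1CCN(Cc2cc(Nc3nc(C)cn4c(-c5cn[nH]c5)cnc34)sn2)CC1` gives 178 ng.h/mL.
Compound 3 `Cc1cn2c(-c3cn[nH]c3)cnc2c(Nc2cc(CN3CCN(S(C)(=O)=O)CC3)ns2)n1` gives "not determined" (no result reported).

Going by the values given here, in an ADME assay on the whole organism (plasma) for pharmacokinetics, with Rattus norvegicus as the target, with a stated time of 6 h, at a dose of 10 mg/kg by the oral route (a higher number here means more compound in the circulation at the dose given, a lower number less compound in the circulation), compound 1 gives 211 ng.h/mL and compound 2 gives 178 ng.h/mL, so the one measured exchange of the group on the saturated chain carbon bound to an aromatic carbon, a 1.2-fold lower number from compound 1 to compound 2 (0.07 log units; within the scatter), left the exposure essentially where it was. On these data alone, compound 3 carries a third group at that same position, but its result is "not determined" (no result reported), so its standing is unknown. Compound 4 `Cc1cn2c(-c3cn[nH]c3)cnc2c(Nc2cc(CN3C[C@H]4CC[C@@H](C3)O4)ns2)n1` differs from compound 3 by a group of 8 heavy atoms (6 carbon, 1 nitrogen, 1 oxygen; one five-membered non-aromatic ring with 1 hetero atom, one six-membered non-aromatic ring with 2 hetero atoms) in place of a group of 10 heavy atoms (5 carbon, 2 nitrogen, 2 oxygen, 1 sulfur; one six-membered non-aromatic ring with 2 hetero atoms), on a saturated chain carbon bound to an aromatic carbon. Among the compounds with values here, because the only comparable exchange gave a 1.2-fold lower number from compound 1 to compound 2 (0.07 log units; within the scatter), no shift beyond the scatter is expected in this assay, and compound 4 is estimated near 190 ng.h/mL, within a range of 60 ng.h/mL to 600 ng.h/mL.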

Compound 4, area under the concentration-time curve: 169 ng.h/mL
Compound 4: the middle estimate sits 1.1-fold (0.05 log units) above what was measured; measured number inside the range.
By their numbers in this assay, from the lowest: compounds 4, 2 and 1 (each within the scatter of the next).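

At the saturated chain carbon bound to an aromatic carbon, a third ring group, with one five-membered and one six-membered non-aromatic ring, now enters the comparison in this assay, with a 1.1-fold lower number from compound 2 to compound 4 (0.02 log units; within the scatter) and a 1.2-fold lower number from compound 1 to compound 4 (0.10 log units; within the scatter). The three different ring groups at this place therefore give exposures that cannot be told apart. Nothing available explains this sameness. Open, on these data alone, is whether an open-chain amine or a carboxylic acid at this place would give a step beyond the scatter. As far as these compounds go, the standing of 4-(methylsulfonyl)piperazin-1-yl also stays open.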